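The source may hold more compounds than are shown below. What is called first, only, known or untested is meant among the compounds shown, and "the series" means these compounds.

In a functional assay on HepG2 cells (Homo sapiens) for antiproliferative activity, read by MTT assay, with a stated time of 48 h (a lower number here means a stronger inhibitor, a higher number a weaker inhibitor), compound 1 `Fc1ccccc1CSc1nnc(-c2cnccn2)o1` gives 12500 nM. Compound 2 `Clc1ccccc1CSc1nnc(-c2cnccn2)o1` carries the change chloro in place of fluoro on an aromatic carbon and in this assay gives 12300 nM; the step of a 1.0-fold lower number from compound 1 to compound 2 (0.01 log units; within the scatter) shows that this swap left the number essentially where it was. Compound 3 `Fc1ccc(CSc2nnc(-c3cnccn3)s2)cc1` is built on a different core, and the difference between the two cores is not broken down here. In this assay compound 3 gives 10100 nM, which sits within the scatter of the numbers for compound 1 and compound 2, so none of the three can be called the stronger inhibitor. Compound 4 `Clc1ccc(CSc2nnc(-c3cnccn3)s2)cc1` has not yet been measured. It differs from compound 3 by chloro in place of fluoro on an aromatic carbon. Among the measured compounds shown here, this is the same kind of change as the one from compound 1 to compound 2, although the place is not identical: in compound 2 the chloro sits ortho to a large group, whereas in compound 4 it sits para to a large group. Because the step of a 1.0-fold lower number from compound 1 to compound 2 (0.01 log units; within the scatter) lay within the scatter, a similarly small step is expected here, a 1.0-fold lower number from compound 3 to compound 4 (0.00 log units; within the scatter). Compound 4 is therefore estimated to give about 10000 nM in this assay, most likely between 5000 nM and 20000 nM.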

Compound 4, half-maximal inhibitory concentration: 6230 nM
Compound 4: middle estimate off by 1.6-fold (0.21 log units), on the high side, within the range that was stated.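

In this assay, chloro in place of fluoro on an aromatic carbon gives a 1.6-fold lower number from compound 3 to compound 4 (0.21 log units; within the scatter), so on this core the swap again moves the number by no more than repeated measurements can vary. Set beside the same swap on the core of compound 1, the two steps cannot be told apart: the same change on two cores in this assay, a 1.0-fold lower number (0.01 log units; within the scatter) from compound 1 to compound 2 and a 1.6-fold lower number (0.21 log units; within the scatter) from compound 3 to compound 4, 1.6-fold (0.20 log units) apart, within the scatter of two such steps. Among the compounds shown here, this shows that, for these two pairs, the swap has the same small outcome on both cores, but it does not show that a larger step would carry over, and it rests on only two pairs, in which the halogen also stands in different places on the ring.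

The compounds shown carry only fluoro or chloro on the six-membered aromatic ring of carbon only. From the compounds shown here alone, it remains open whether a different group there, such as an amine, a carboxylic acid or a longer chain, would move the number beyond the scatter, and whether such a step would match on the two cores.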